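Working notes: aryl exchange from compound 2 to compound 3

The compounds below may be only part of what the source reports. "The series", "measured", "known", "first", "only" and "open" are said of these compounds alone.

- compound 1 (`C=C1CCC[C@]2(C)CCC(c3cn(-c4ccc(C(C)=O)cc4)nn3)=CC[C@@]12C`): 46400 nM
- compound 2 (`C=C1CCC[C@]2(C)CCC(c3cn(-c4cccc(OC)c4)nn3)=CC[C@@]12C`): 11200 nM

Among the compounds with values here, in a functional assay on A549 cells (Homo sapiens) for cytotoxicity, read by MTT assay, with a stated time of 48 h (a lower number here means a stronger inhibitor, a higher number a weaker inhibitor), compound 2 stands at 11200 nM and is the lower of the two measured numbers, with compound 1 at 46400 nM as its only neighbour. Compound 3 (`C=C1CCC[C@]2(C)CCC(c3cn(-c4ccc(Cl)cc4)nn3)=CC[C@@]12C`) keeps the shared core and carries 4-chlorophenyl in place of 3-methoxyphenyl on an aromatic nitrogen.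

Within the data shown here, only one measured step bears on this change. It is a 4.1-fold lower number from compound 1 to compound 2 (0.62 log units; beyond the scatter) and it comes from the exchange of 4-acetylphenyl for 3-methoxyphenyl at the same place. That step is modest but beyond the scatter. Among the measured compounds shown here, compound 3 gives up the 3-methoxyphenyl group, as compound 1 lacks it, but chlorine is not acetyl, and no measured compound carries 4-chlorophenyl. One step is thin support, so the range is kept wide. A modest rise in this assay is expected, smaller than the step measured between the two known compounds.

The expected change is a 2.2-fold higher number from compound 2 to compound 3 (0.35 log units; beyond the scatter) on this estimate. For compound 3 the estimated value is 25000 nM within an expected range of 9000 nM to 60000 nM in this read-out.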

Compound 3, half-maximal inhibitory concentration: 20100 nM
Estimate against measurement, compound 3: 1.2-fold (0.09 log units) above, and the stated range covers the measured number.
By their numbers in this assay, from the lowest: compounds 2 and 3 (each within the scatter of the next); then compound 1.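

In this assay, 4-chlorophenyl in place of 3-methoxyphenyl on the aromatic nitrogen gives a 1.8-fold higher number from compound 2 to compound 3 (0.25 log units; within the scatter), so this exchange does not separate the two aryl groups, and the 3-methoxyphenyl group is not required for a number at this level. Chloro in place of acetyl on the phenyl ring gives a 2.3-fold lower number from compound 1 to compound 3 (0.36 log units; beyond the scatter), a modest step beyond the scatter, which shows that compound 1 also stands apart from a second aryl group and not only from the 3-methoxyphenyl of the earlier comparison. No measurement at hand offers an explanation for either step.

On these data alone, all three numbers come from this assay, so it remains open whether the pattern holds in any other cell line or read-out. As far as these compounds go, it is also open whether a different group on this nitrogen, such as an aminophenyl, a carboxyphenyl or a plain alkyl chain in place of the aryl ring, would give a number clearly apart from those of compound 2 and compound 3.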